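A few compounds are considered here, and "the series" means these few. Any claim that something is new, unique, unknown or untested is made for them only; others in the source may bear on it.

Working notes on the series

Compound 1 `Nc1nc2cc(Cl)c(Cl)cc2n1Cc1cccc(C(F)(F)F)c1` and compound 2 `Nc1nc2cc(Cl)c(Cl)cc2n1Cc1cccc([N+](=O)[O-])c1` share one core; compound 3 `FC(F)(F)c1ccc(Cn2c(Br)nc3cc(Cl)c(Cl)cc32)cc1` and the not yet measured compound 4 `O=[N+]([O-])c1ccc(Cn2c(Br)nc3cc(Cl)c(Cl)cc32)cc1` share another. How the core of compound 3 differs from the core of compound 1 is not broken down here.

In a functional assay on KB cells (Homo sapiens) for inhibition (a higher number here means a weaker inhibitor, a lower number a stronger inhibitor), compound 1 gives 45000 nM. Compound 2 gives 65000 nM in this assay. The change between them is nitro in place of trifluoromethyl on an aromatic carbon, and the step of a 1.4-fold higher number from compound 1 to compound 2 (0.16 log units; within the scatter) shows that in this pairing the swap leaves the read-out where it was.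

Compound 3 sits at the limit of this assay, (the limit of > 100000 nM in this assay, at which 1 of the 3 values shown sits), so only a bound and no number is known for it. In this assay compound 3 gives > 100000 nM.

The change from compound 3 to compound 4 is nitro in place of trifluoromethyl on an aromatic carbon. It is the same kind of change as that from compound 1 to compound 2, not the same: in the first pair the group sits meta to a large group, in the second para to a large group.

The step is expected to be a step that the limit leaves unreadable from compound 3 to compound 4 in this assay, resting on the step from compound 1 to compound 2 a 1.4-fold higher number from compound 1 to compound 2 (0.16 log units; within the scatter), which stayed within scatter, and on compound 3 already sitting at > 100000 nM. For compound 4 the estimate in this assay is 150000 nM, with a range from 70000 nM to 400000 nM, and a limit rather than a number is expected to be the most likely outcome.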

Compound 4, half-maximal inhibitory concentration: 40000 nM
Estimate against measurement, compound 4: 3.8-fold (0.57 log units) above; the whole stated range lies above it.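

Nitro in place of trifluoromethyl gives an at least 2.5-fold lower number from compound 3 to compound 4 (0.39 log units; beyond the scatter) in this assay, so on the evidence of these two pairs the change does not carry over from one core to the other with the same result: the same change on two cores in this assay, a 1.4-fold higher number (0.16 log units; within the scatter) from compound 1 to compound 2 and an at least 2.5-fold lower number (0.39 log units; beyond the scatter) from compound 3 to compound 4, at least 3.6-fold (0.55 log units) apart, beyond the scatter of two such steps

Compound 3 has only a limit, > 100000 nM, and not a number, so the second step has a lower bound but no known size: the limit of > 100000 nM in this assay, at which 1 of the 4 values shown sits.

The two pairs differ in the position of the group on the ring as well as in the core, and with a single pair on each core the gap between the steps cannot be assigned to either difference, nor does it show why the result changes.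

Left open is what the same change would give on each core with the group in the position it holds on the other, which would separate position from core. Also open, on these data alone, is how other groups in that place, such as a nitrile, a carboxylic acid or an amine, would read in this assay on either core, and whether any of them would follow one pair or the other.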